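A few compounds are considered here, and "the series" means these few. Any claim that something is new, unique, unknown or untested is made for them only; others in the source may bear on it.

In a functional assay (brain) for displacement of a labelled ligand, with Rattus norvegicus as the target (a lower number here means a stronger inhibitor, a higher number a weaker inhibitor), compound 1 `CN1CCCC[C@H]1[C@H]1COC(c2ccccc2)(c2ccccc2)O1` gives 4400 nM. Among the compounds with values here, compound 2 `C=CCN1CCCC[C@H]1[C@H]1COC(c2ccccc2)(c2ccccc2)O1` gives 15200 nM in this assay and so stands at the higher of the two numbers measured so far; the step of a 3.5-fold higher number from compound 1 to compound 2 (0.54 log units; beyond the scatter) put vinyl in place of hydrogen on a saturated chain carbon bound to an amine nitrogen in a ring. Compound 3 `c1ccc(CN2CCCC[C@H]2[C@H]2COC(c3ccccc3)(c3ccccc3)O2)cc1` carries the same change one bond further out: phenyl in place of vinyl on a saturated chain carbon bound to an amine nitrogen in a ring. Within the data shown here, only that one step bears on it, and it weakened binding, so a further modest rise in this assay is expected, a 2.0-fold higher number from compound 2 to compound 3 (0.30 log units; within the scatter). Compound 3 is estimated at 30000 nM, range 8000 nM to 100000 nM.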

Compound 3, inhibition constant: 10100 nM
Compound 3: middle estimate off by 3.0-fold (0.47 log units), on the high side; the range from low to high includes it.
By their numbers in this assay, from the lowest: compound 1; then compounds 3 and 2 (each within the scatter of the next).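

At this position, on a saturated chain carbon bound to an amine nitrogen in a ring, phenyl and vinyl are not separated in this assay (a 1.5-fold lower number from compound 2 to compound 3 (0.18 log units; within the scatter)). Compound 3 still reads weaker than compound 1 (a 2.3-fold higher number from compound 1 to compound 3 (0.36 log units; beyond the scatter)), so the loss in binding seen with vinyl also appears with phenyl. Nothing available explains these numbers.

Open, from the compounds shown here alone, is how a hydrogen on the amine nitrogen in place of methyl would read. Also open, going by these compounds, is whether a longer chain such as phenylethyl would stay at the level of compound 3 or return towards compound 1.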